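Swapping the Aryl Group in a Receptor Agonist Series

A few compounds are considered here, and "the series" means these few. Any claim that something is new, unique, unknown or untested is made for them only; others in the source may bear on it.

Of the compounds shown here, three have been measured in a functional assay on isolated protein with Glucose-dependent insulinotropic receptor (Mus musculus) as the target, read by HTRF and cAMP accumulation, with a stated time of 45 min; on this read-out higher numbers stand for larger maximal responses and lower numbers for smaller maximal responses. Compound 3 `C[C@@H]1CN(C(=O)OC(C)(C)C)CCN1c1ncc(OCc2ccc(C#N)cc2)cn1` gives 88% in this assay, the second highest of the three numbers. Compound 2 `C[C@@H]1CN(C(=O)OC(C)(C)C)C[C@H](C)N1c1ncc(OCc2ccc(S(C)(=O)=O)cc2)cn1` gives 95%, a number within the scatter of compound 3, so the two cannot be told apart on this read-out. Compound 1 `C[C@@H]1CN(c2ncc(OCc3ccc(S(C)(=O)=O)cc3)cn2)CCN1C(=O)OC(C)(C)C` gives 16%, far below compound 3 and well beyond the scatter. Compound 4 `Cc1cnccc1COc1cnc(N2CCN(C(=O)OC(C)(C)C)C[C@H]2C)nc1` has not yet been measured. It differs from compound 3 in a single place: 3-methylpyridin-4-yl in place of 4-cyanophenyl on a saturated chain carbon bound to an oxygen on an aromatic ring. Within the data shown here, no measured pair shows this particular change, so its effect rests on expectation alone. A moderate drop beyond the scatter is expected, with the step from compound 3 to compound 4 estimated at a number 18 percentage points lower from compound 3 to compound 4 (beyond the scatter). Compound 4 is therefore expected to give 70%, within a range from 35% to 95%.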

Compound 4, intrinsic activity: the largest response reached, in percent of the reference agonist's: 60%
Compound 4: middle estimate off by 10 percentage points, on the high side; the range from low to high includes it.
By their numbers in this assay, from the lowest: compound 1; then compound 4; then compounds 3 and 2 (each within the scatter of the next).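

In this assay, 3-methylpyridin-4-yl in place of 4-cyanophenyl on a saturated chain carbon bound to an oxygen on an aromatic ring gives a number 28 percentage points lower from compound 3 to compound 4 (beyond the scatter), the only measured change at this place among the compounds shown. The response falls but is not lost, as compound 4 still gives 60% with a nitrogen-containing aromatic ring here. Nothing available explains this step. Going by these compounds, whether plain pyridin-4-yl, without the methyl, or 3-methylphenyl would hold the response stays open, as does the size of this step on the core of compound 2.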